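The compounds below may be only part of what the source reports. "The series", "measured", "known", "first", "only" and "open" are said of these compounds alone.

Compound 2 `O=C(OC[C@H]1CN(c2ccc(-n3cc(-c4ccccn4)cn3)c(F)c2)C(=O)O1)c1ccccc1` stands highest of the two numbers in a physicochemical assay for lipophilicity, read by HPLC, measured as octanol-water partition (on this read-out lower numbers stand for lower lipophilicity and higher numbers for higher lipophilicity), where compound 2 gives 4.21. Compound 1 `O=C1CNC(=O)N1C[C@H]1CN(c2ccc(-n3cc(-c4ccccn4)cn3)c(F)c2)C(=O)O1` gives 1.25 in this assay. Within the data shown here, the only step known so far, a number 2.96 log units higher from compound 1 to compound 2 (beyond the scatter), shows how strongly the benzoyloxy group raises this read-out. Compound 3 `O=C1O[C@@H](Cn2ccnn2)CN1c1ccc(-n2cc(-c3ccccn3)cn2)c(F)c1` carries 1H-1,2,3-triazol-1-yl in place of benzoyloxy on a saturated chain carbon bound to a saturated ring carbon. Since the same benzoyloxy leaves here, a large drop is expected, though a triazolyl group need not pull the number as low as the dioxoimidazolidinyl of compound 1 did. For compound 3 the expected step is a number 2.01 log units lower from compound 2 to compound 3 (beyond the scatter), giving an estimated 2.2, likely between 1.5 and 2.9.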

Compound 3, partition coefficient: 2
The estimate for compound 3 lay 0.20 log units above the measured number; the measured number falls inside the stated range.
By their numbers in this assay, from the lowest: compound 1; then compound 3; then compound 2.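

Replacing benzoyloxy at this place, on a saturated chain carbon bound to a saturated ring carbon, lowers the number in this assay with a second group too: 1H-1,2,3-triazol-1-yl gives a large fall (a number 2.21 log units lower from compound 2 to compound 3 (beyond the scatter)). The two replacements do not end at the same level, as 1H-1,2,3-triazol-1-yl reads modestly above 2,5-dioxoimidazolidin-1-yl (a number 0.75 log units higher from compound 1 to compound 3 (beyond the scatter)). Nothing available explains these differences. Where an amine, a carboxylic acid or a longer alkyl chain at this place would fall relative to these three compounds remains open.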